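The source may hold more compounds than are shown below. What is called first, only, known or untested is meant among the compounds shown, and "the series" means these compounds.

Working notes on the series. Compound 1 `COc1ccc(/C=C/C(=O)O)c(OC(=O)c2nc(C)c(C)nc2C)c1`, compound 2 `CCOC(=O)/C=C/c1ccc(OC(=O)c2nc(C)c(C)nc2C)c(O)c1` and compound 3 `CCOC(=O)/C=C/c1ccc(OC(=O)c2nc(C)c(C)nc2C)cc1` have been measured; compound 4 `Cc1nc(C)c(C(=O)Oc2ccc(/C=C/C(=O)O)cc2)nc1C` has not. In a functional assay on EA.hy 926 cells (Homo sapiens) for cytotoxicity, read by MTT assay, with stated times of 24 h and 12 h (on this read-out lower numbers stand for an effect already at smaller amounts and higher numbers for an effect only at larger amounts of compound), compound 1 gives 115000 nM, compound 2 gives 1700 nM and compound 3 gives 34900 nM. Compound 3 thus stands second highest of the three numbers, nearer to compound 1 than to compound 2. For the measured compounds named here, the only measured step, a 21-fold higher number from compound 2 to compound 3 (1.31 log units; beyond the scatter), concerns an aromatic position and does not bear on the present change. Compound 4 differs from compound 3 by hydrogen in place of ethyl on an oxygen next to a carbonyl group. Going by the values given here, no measured step covers this change; compound 1, the sole compound with a carboxy group, gives the highest number so far, which leans toward a higher number for compound 4. Compound 4 is therefore expected near 70000 nM, with a range of 20000 nM to 250000 nM. The expected step of a 2.0-fold higher number from compound 3 to compound 4 (0.30 log units; within the scatter) may well stay within the scatter.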

Compound 4, half-maximal effective concentration: 38000 nM
The estimate for compound 4 lay 1.8-fold (0.27 log units) above the measured number; measured number inside the range.
By their numbers in this assay, from the lowest: compound 2; then compounds 3 and 4 (each within the scatter of the next); then compound 1.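

In this assay, this position tolerates the exchange: hydrogen in place of ethyl on an oxygen next to a carbonyl group gives a 1.1-fold higher number from compound 3 to compound 4 (0.04 log units; within the scatter). On this pair, the ethoxycarbonyl and carboxy forms cannot be told apart, so the ethyl group makes no difference that can be read beyond the scatter. No measured evidence addresses why the two forms read alike. Open, as far as these compounds go, is whether a longer chain such as butyl on that oxygen, or an amide in place of the ester, would read alike. Also open, from the compounds shown here alone, is whether the same exchange would read alike with the hydroxy group of compound 2 present.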